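Trimming the side group of compound 2

The compounds below may be only part of what the source reports. "The series", "measured", "known", "first", "only" and "open" are said of these compounds alone.

Values measured so far in a functional assay on HL-60 cells (Homo sapiens) for inhibition (on this read-out lower numbers stand for stronger inhibition and higher numbers for weaker inhibition), are these.
compound 1 `COc1ccc(-c2cc(O)nnc2-c2ccc(OC)cc2)cc1` gives 31600 nM
compound 2 `COc1ccc(-c2cc(=O)n(Cc3cccnc3)nc2-c2ccc(OC)cc2)cc1` gives 430 nM

Of these two numbers, the lower belongs to compound 2, so it is the stronger inhibitor, and the gap to compound 1 lies well beyond the usual scatter of repeated measurements.

Compound 3 `CCn1nc(-c2ccc(OC)cc2)c(-c2ccc(OC)cc2)cc1=O` has not been measured yet. It differs from compound 2 in one place. The change is methyl in place of pyridin-3-yl on a saturated chain carbon bound to an aromatic nitrogen and, in words, methyl in place of pyridin-3-yl on a saturated chain carbon bound to an aromatic nitrogen. Cut one bond further out, (pyridin-3-yl)methyl gives way to ethyl.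

Going by the values given here, no measured pair shows this change, so the size of the step in this assay remains a judgement. Compound 2 at 430 nM holds the better of only two numbers, and compound 1 at 31600 nM shows how high a number can go among these compounds. A moderate rise, beyond the scatter, is therefore expected. The expected change is a 3.5-fold higher number from compound 2 to compound 3 (0.54 log units; beyond the scatter) as an estimate. For compound 3 the estimated value is 1500 nM within an expected range of 400 nM to 8000 nM in this measurement.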

Compound 3, half-maximal inhibitory concentration: 610 nM
For compound 3 the middle estimate is 2.5-fold (0.39 log units) above the measured one, within the range that was stated.
By their numbers in this assay, from the lowest: compounds 2 and 3 (each within the scatter of the next); then compound 1.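

The step of a 1.4-fold higher number from compound 2 to compound 3 (0.15 log units; within the scatter) in this assay shows that this position tolerates a large change: (pyridin-3-yl)methyl gives way to ethyl, and the number stays within the usual scatter. On the saturated chain carbon bound to an aromatic nitrogen, the whole pyridin-3-yl ring can therefore be replaced by a single methyl without a reading that can be told apart, so compound 2 and compound 3 stand level on this read-out, and the ring is not required to keep the number at this level. The compounds shown offer no separate measurement that could explain this result.

Going by these compounds alone, what remains open is whether anything at this position moves the number beyond the scatter, since only two groups have been compared here. A phenyl ring in place of pyridin-3-yl would test whether the ring nitrogen plays any part, while a longer chain such as butyl, or a chain ending in an amine or a carboxylic acid, would show how much more this position accepts.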